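A few compounds are considered here, and "the series" means these few. Any claim that something is new, unique, unknown or untested is made for them only; others in the source may bear on it.

Measured compounds:
- compound 1, `C/C(=N\NC(=S)Nc1ccccc1[N+](=O)[O-])c1ccccn1`: 5.7 nM
- compound 2, `CC(=NNC(=S)Nc1ccccc1)c1ccccn1`: 0.18 nM
- compound 3, `C/C(=N\NC(=S)Nc1ccccc1Cl)c1ccccn1`: 0.16 nM

The three compounds share one core and differ only in the group on one aromatic carbon of the phenyl ring. In a functional assay on MCF7 cells (Homo sapiens) for cytotoxicity, read by MTT assay, with a stated time of 48 h (a higher number here means a weaker inhibitor, a lower number a stronger inhibitor), compound 3 gives the lowest of the three numbers, but compound 2 sits within the scatter of it, so no order between the two can be claimed; only compound 1 stands apart, and the step of a 36-fold lower number from compound 1 to compound 3 (1.55 log units; beyond the scatter) is large.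

The unmeasured compound 4, `C/C(=N\NC(=S)Nc1ccccc1)c1ccccn1`, follows from compound 3 by hydrogen in place of chloro on an aromatic carbon.

Among the compounds with values here, of the measured steps, only the one from compound 1 to compound 3 touches this position, and it concerns a different pair of groups, so it bears on the present change only by showing that the position is sensitive. Closer to the point is compound 2, which already carries hydrogen on that aromatic carbon and in this assay gives 0.18 nM, a number within the scatter of compound 3. On that basis the step of a 1.1-fold higher number from compound 3 to compound 4 (0.05 log units; within the scatter) is expected to stay within the scatter, with no clear direction. Compound 4 is therefore estimated at 0.18 nM, with a range from 0.07 nM to 0.5 nM.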

Compound 4, half-maximal inhibitory concentration: 0.18 nM
For compound 4 middle estimate and measured number coincide at the digits printed; low and high end bracket the measured number.
By their numbers in this assay, from the lowest: compounds 3, 2 and 4 (each within the scatter of the next); then compound 1.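

With compound 4 in hand, hydrogen and chloro on this aromatic carbon can be compared directly as a single change: in this assay, the step of a 1.1-fold higher number from compound 3 to compound 4 (0.05 log units; within the scatter) shows that losing chloro leaves the number within the scatter. The step of a 32-fold lower number from compound 1 to compound 4 (1.50 log units; beyond the scatter) is large, like the step of a 36-fold lower number from compound 1 to compound 3 (1.55 log units; beyond the scatter), so among the groups shown, the sensitivity of this position rests on nitro alone, while hydrogen and chloro cannot be told apart. Compound 4 also adds a pair that shares all atoms and bonds, and the result no change at the digits printed from compound 2 to compound 4 (within the scatter) gives no sign of a difference, though the two are separated only by how one double bond is drawn: the fact that one of compounds 2 and 4 is drawn with a defined configuration and the other without, at the place where they differ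

The compounds shown leave open how an amine, a methoxy group or a carboxylic acid on this aromatic carbon would read, and so whether nitro stands alone or is one of several groups that give a higher number. They also leave open which configuration compound 2 holds at that double bond, and therefore whether compounds 2 and 4 are one substance or two.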